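A Fluorine Shift Tested on Two Related Cores

This account rests on a few compounds, and the source may have more. Where it says the series, first, only, none or still open, it means among the compounds named here.

Measured compounds:
Compound 1 `O=c1[nH]cc(S(=O)(=O)Nc2ccccc2-c2cn(-c3ccccc3F)nn2)c(=O)[nH]1`: 12500 nM
Compound 2 `O=c1[nH]cc(S(=O)(=O)Nc2ccccc2-c2cn(-c3cccc(F)c3)nn2)c(=O)[nH]1`: > 20000 nM, recorded only as a limit
Compound 3 `O=c1[nH]cc(S(=O)(=O)Nc2cccc(-c3cn(-c4ccccc4F)nn3)c2)c(=O)[nH]1`: 13900 nM

In a functional assay on HepG2 cells (Homo sapiens) for antiproliferative activity, read by MTT assay, with a stated time of 24 h (on this read-out lower numbers stand for stronger inhibition and higher numbers for weaker inhibition), compound 1 gives 12500 nM. Compound 2 does not reach a number in this assay; its result is a limit, > 20000 nM. The change between them is 3-fluorophenyl in place of 2-fluorophenyl on an aromatic nitrogen, and it produced an at least 1.6-fold higher number from compound 1 to compound 2 (0.20 log units; that floor lies within the scatter); that one of the values sits at the limit is shown by the limit of > 20000 nM in this assay, at which 1 of the 3 values shown sits. Compound 3 gives 13900 nM in this assay, a result within the scatter of compound 1. The difference between the cores of compound 1 and compound 3 is not broken down here.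

Compound 4 `O=c1[nH]cc(S(=O)(=O)Nc2cccc(-c3cn(-c4cccc(F)c4)nn3)c2)c(=O)[nH]1` is not yet measured. It differs from compound 3 by 3-fluorophenyl in place of 2-fluorophenyl on an aromatic nitrogen, the same change as between compound 1 and compound 2, at the same place. Resting on that measured step, compound 4 is expected to show a 1.8-fold higher number from compound 3 to compound 4 (0.25 log units; within the scatter) in this assay. Compound 4 is therefore estimated at 25000 nM, with a likely range from 12000 nM to 60000 nM, and a real chance that only a limit is reported.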

Compound 4, half-maximal inhibitory concentration: > 20000 nM
Compound 4: only a limit was reported; the forecaster's own chance of this, stated with the estimate: 55%; the middle value lies beyond the limit too.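

Compound 4 is recorded in this assay only as a limit, > 20000 nM. Placing 3-fluorophenyl where 2-fluorophenyl stood on the second core gives an at least 1.4-fold higher number from compound 3 to compound 4 (0.15 log units; that floor lies within the scatter). On both cores, the compound carrying 3-fluorophenyl ends at a limit rather than a number, so the two results agree in that plain sense, but the true size of the change remains unknown on either core, and a matching effect across the cores is not shown: the same change on two cores in this assay, an at least 1.6-fold higher number (0.20 log units; that floor lies within the scatter) from compound 1 to compound 2 and an at least 1.4-fold higher number (0.15 log units; that floor lies within the scatter) from compound 3 to compound 4; the limit leaves it open whether they differ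

Any further loss of activity among these compounds would stay hidden, and this ceiling restricts what can be compared: the limit of > 20000 nM in this assay, at which 2 of the 4 values shown sit. Also open is whether a phenyl without fluorine, or a phenyl carrying a methoxy group or an amine in place of the fluorine, would give a number in this assay on either core.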